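A chloro step from compound 2 to compound 3

The source may hold more compounds than are shown below. What is called first, only, known or untested is meant among the compounds shown, and "the series" means these compounds.

In a functional assay on HO8910 cells (Homo sapiens) for inhibition, read by MTT assay, with a stated time of 24 h, tested at 0.1 ug/mL (a lower number here means less inhibition of growth, a higher number more inhibition of growth at the concentration tested), compound 1 (`O=C(CCCCC(S)CCS)NO`) is reported as "not active" (no number reported) with no number given. Going by the values given here, compound 2 (`O=C(CCCCC(S)CCS)Nc1ccccc1`) gives 7.37% as the only number available, so it has no second measured value to be ranked against. Compound 3 (`O=C(CCCCC(S)CCS)Nc1cccc(Cl)c1`) keeps the core of compound 2 and differs from it in one place (chloro in place of hydrogen on an aromatic carbon), with chloro in place of hydrogen on an aromatic carbon. No measured step shows what such a change does among these compounds. The only numerical starting point is compound 2 at 7.37% and a slight rise, not clearly beyond the usual scatter, is expected from it. The expected step is a number 2.6 percentage points higher from compound 2 to compound 3 (within the scatter) on this estimate. For compound 3 the estimated value is 10% (expected range 2% to 25%).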

Compound 3, percent growth inhibition at one concentration: "not active" (no number reported)
Nothing numeric was reported for compound 3; there is nothing to compare the estimate with.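

Going by these compounds alone, compound 3 carries no number in this assay, so no step from compound 2 to compound 3 can be read. No evidence bears on this result. The compounds shown leave open what a chloro group on the aromatic ring does to growth inhibition.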